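This account rests on a few compounds, and the source may have more. Where it says the series, first, only, none or still open, it means among the compounds named here.

Measured compounds:
- compound 1, `COc1cc(-c2cc(/C=C/C(=O)c3ccc(N)cc3)[nH]n2)cc(OC)c1OC`, 97%
- compound 2, `COc1ccc(-c2cc(/C=C/C(=O)c3ccc(N)cc3)[nH]n2)cc1OC`, 93%
- compound 3, `COc1cc(C(=O)/C=C/c2cc(-c3cc(OC)c(OC)c(OC)c3)n[nH]2)cc(OC)c1OC`, 100%

Three compounds of this series were tested in a functional assay on ACHN cells (Homo sapiens) for cytotoxicity, read by sulforhodamine B assay, with a stated time of 48 h, tested at 0.1 uM; a lower number here means a stronger effect, a higher number a weaker effect of the compound at the concentration tested. Compound 1 gives 97%. Compound 2 gives 93%. The two differ only in hydrogen in place of methoxy on an aromatic carbon, and that change made a step of a number 4 percentage points lower from compound 1 to compound 2 (within the scatter). In this assay compound 3 gives 100%. Compound 3 and compound 1 differ by more than a single group, and the difference between the two cores is not broken down here; their two values lie within the scatter of each other, as do those of compound 3 and compound 2.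

Compound 4, `COc1ccc(-c2cc(/C=C/C(=O)c3cc(OC)c(OC)c(OC)c3)[nH]n2)cc1OC`, has not yet been measured. It differs from compound 3 by hydrogen in place of methoxy on an aromatic carbon. Among the measured compounds shown here, this is the same change as the one from compound 1 to compound 2, made at a place described in the same words. For the measured compounds named here, on the strength of the single earlier step, which for compound 1 and compound 2 stayed within the scatter, the step from compound 3 to compound 4 in this assay is expected to be of similar size, a number 4 percentage points lower from compound 3 to compound 4 (within the scatter). Compound 4 is therefore estimated to give 96%, with a likely range from 86% to 102%. This rests on one pair only, and the shift in the rest of the molecule between compound 1 and compound 3 is not accounted for.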

Compound 4, a percentage reported as activity, at one concentration (the size of the read-out at that concentration, not a potency): 91%
Beside the measured number, compound 4's estimate is 5 percentage points above it; low and high end bracket the measured number.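

In this assay, hydrogen in place of methoxy on an aromatic carbon gave a number 9 percentage points lower from compound 3 to compound 4 (within the scatter), so on this second core, as on the first, the step cannot be told from the usual scatter. Set beside the earlier step, the new one agrees with it, and the two cores give no sign of treating the change differently: the same change on two cores in this assay, a number 4 percentage points lower (within the scatter) from compound 1 to compound 2 and a number 9 percentage points lower (within the scatter) from compound 3 to compound 4, 5 percentage points apart, within the scatter of two such steps. Among the compounds shown here, this shows only that the change, carried from the core of compound 1 to the core of compound 3, produced no step beyond the scatter on either; it does not show that the change has a real effect on either core or that the two steps share a cause, and with two pairs read at a single concentration, it says nothing of potency or of how the change would behave on any further core.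

The compounds shown leave open whether another group at this place on the six-membered aromatic ring of carbon only, such as a fluorine, a hydroxyl or a carboxylic acid, would give a step beyond the scatter. They also leave open whether the removal of a methoxy group at any other place in these molecules would do so.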